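The source may hold more compounds than are shown below. What is called first, only, known or untested is meant among the compounds shown, and "the series" means these compounds.

Measured compounds:
- compound 1, `N#Cc1cnn(C(=O)NCc2ccc(OCc3ccccc3)cc2)c1`: > 100000 nM
- compound 2, `Cc1cnn(C(=O)N2CCCCC2)c1`: > 100000 nM

In an assay on membranes from brain for binding affinity to neutral cholesterol ester hydrolase 1 (Mus musculus), read by fluorescence, with stated times of 1 h and 30 min (a lower number here means a stronger inhibitor, a higher number a weaker inhibitor), compound 1 gives > 100000 nM, which is a limit of the assay rather than a number. Compound 2 gives > 100000 nM in this assay, again a limit and not a number. Among the compounds with values here, compound 2 therefore stands at the limit of > 100000 nM in this assay, at which 2 of the 2 values shown sit, so nothing finer than that limit is known about it, and no step between two measured compounds can be drawn from these two values.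

The next compound, compound 3 `O=C(N1CCCCC1)n1cccn1`, comes from compound 2 by hydrogen in place of methyl on an aromatic carbon. With compound 2 known only as a limit, the expected step in this assay is none beyond the scatter, which means an expected a number no higher from compound 2 to compound 3 (the limit leaves the size open). Compound 3 is therefore expected to give about 100000 nM in this assay, within a range from 30000 nM to 300000 nM, most likely again reported as a limit.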

Compound 3, half-maximal inhibitory concentration: > 100000 nM
Compound 3 ended at the assay's limit; the forecaster's own chance of this, stated with the estimate: 85%; the middle value lies on the limit itself.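

Compound 2 and compound 3 both rest at a limit of this assay rather than at a number, so no step can be read for hydrogen in place of methyl: the limit of > 100000 nM in this assay, at which 3 of the 3 values shown sit. The compounds shown leave open how strongly any of them inhibits, and which change would give a readable number.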